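Swapping the isopropyl on the carbonyl of compound 2

The source may hold more compounds than are shown below. What is called first, only, known or untested is meant among the compounds shown, and "the series" means these compounds.

In an ADME assay on microsomes from liver (Homo sapiens) for metabolic stability (a higher number here means faster removal of the compound, a lower number slower removal), compound 2 `Cc1ccc(C(=O)Nc2cn3ncnc3c(CN3CCN(C(=O)C(C)C)[C@@H](C)C3)c2C)cn1` gives 240 mL.min-1.g-1 and stands highest of the three measured compounds. Compound 1 `Cc1ccc(C(=O)Nc2cc3nncn3c(CN3CCN(C(=O)C4CCCC4)[C@@H](C)C3)c2C)cn1` is nearest at 59 mL.min-1.g-1 and compound 3 `Cc1ccc(C(=O)Nc2cn3ncnc3c(CN3CCN(C(=O)CC(C)C)[C@@H](C)C3)c2C)cn1` is furthest at 20 mL.min-1.g-1 in the same read-out, both gaps lying beyond the scatter.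

Compound 4 `Cc1ccc(C(=O)Nc2cn3ncnc3c(CN3CCN(C(=O)C4CCC(F)(F)C4)[C@@H](C)C3)c2C)cn1` is still unmeasured. It differs from compound 2 as 3,3-difluorocyclopentyl in place of isopropyl on a carbonyl carbon with 3,3-difluorocyclopentyl in place of isopropyl on a carbonyl carbon.

Among the measured compounds shown here, only one measured step changes this group on the core of compound 2. That step is large and beyond the scatter, a 12-fold lower number from compound 2 to compound 3 (1.08 log units; beyond the scatter) with isobutyl in place of isopropyl on a carbonyl carbon. For the measured compounds named here, compound 1 also has a five-membered ring of carbon only on its carbonyl, without fluorine, but its core differs and no measured step links it to compound 2. It offers only weak support. Going by the values given here, no measured compound carries fluorine, and a single step sets no pattern, so a lower number is expected with wide uncertainty, probably less of a drop than the isobutyl step gave. The expected size is a 4.8-fold lower number from compound 2 to compound 4 (0.68 log units; beyond the scatter) as a working figure. Compound 4 is estimated at 50 mL.min-1.g-1 with 15 mL.min-1.g-1 to 150 mL.min-1.g-1 as the expected range.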

Compound 4, intrinsic clearance in microsomes: < 10 mL.min-1.g-1
Compound 4: only a limit was reported (the forecaster's own chance of this, stated with the estimate: 3%); at least 5.0-fold (0.69 log units) between middle value and limit.
By their numbers in this assay, from the lowest: compound 3; then compound 1; then compound 2. At a limit, below all of these: compound 4.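

In this assay, both replacements of isopropyl on this carbonyl carbon lower the number on the shared core: 3,3-difluorocyclopentyl gives an at least 24-fold lower number from compound 2 to compound 4 (1.38 log units; beyond the scatter), joining the isobutyl step, a 12-fold lower number from compound 2 to compound 3 (1.08 log units; beyond the scatter), so a second, ring-bearing group now points the same way as the open-chain one, and among these three compounds, compound 2 alone stands high. The new group does not separate clearly from isobutyl, however: the change gives an at least 2.0-fold lower number from compound 3 to compound 4 (0.30 log units; that floor lies within the scatter), and with that floor inside the scatter, no order of compound 3 and compound 4 can be claimed. The result for compound 4 is a limit and not a number: the limit of < 10 mL.min-1.g-1 in this assay, at which 1 of the 4 values shown sits.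

Still open is whether the drop follows from the carbon ring or from the two fluorine atoms, since the plain cyclopentyl of compound 1 sits on a different core and no listed step links it to this series. Also open, going by these compounds, is how this carbonyl position responds to a longer carbon chain, or to a group carrying an amine or a carboxylic acid.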